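The compounds below may be only part of what the source reports. "The series", "measured", "known", "first", "only" and "open" are said of these compounds alone.

Two measured compounds frame this account. For the measured compounds named here, compound 1 `CCCCC[Se]c1nc([Se]CCCCC)c2ccccc2n1` is the starting point, and compound 2 `CSc1nc(Nc2ccccc2)c2ccccc2n1` is the only other compound with a recorded value. In a functional assay on CCRF-CEM cells (Homo sapiens) for cytotoxicity, read by MTT assay, with a stated time of 72 h (on this read-out higher numbers stand for lower toxicity in this test and lower numbers for higher toxicity in this test), compound 1 gives > 100000 nM, which is a limit of the assay and not a number. In this assay compound 2 gives > 100000 nM, again a limit rather than a measured value. Compound 1 therefore stands at the ceiling of what this assay reports, as summarised by the limit of > 100000 nM in this assay, at which 2 of the 2 values shown sit, and no order between the two compounds can be read from these figures.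

The step under consideration leads to compound 3 `CCCCC[Se]c1nc(N)c2ccccc2n1`, in which (one nitrogen atom in place of a group of 6 heavy atoms (5 carbon, 1 selenium; no ring), on an aromatic carbon). Going by the values given here, no step between two measured compounds is available, so nothing beyond the two limits guides the expectation. For compound 3 the expected step of a number no higher from compound 1 to compound 3 (the limit leaves the size open) is none beyond the scatter, most probably with the result again reported only as a limit. The value estimated for compound 3 in this assay is 100000 nM, with an expected range from 30000 nM to 300000 nM.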

Compound 3, concentration lethal to 50% of the cells: > 100000 nM
Compound 3: no number, only a limit; the forecaster's own chance of this, stated with the estimate: 75%; the middle value sits exactly at the limit.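

In this assay compound 3 gives > 100000 nM, a limit of the assay and not a number. No step from compound 1 to compound 3 can be read, because both compounds stand at the same limit: the limit of > 100000 nM in this assay, at which 3 of the 3 values shown sit.

The compounds shown leave open whether any change to the shared core would give a measurable value in this assay.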